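Replacing Ethyl with 4-Bromophenyl on the Imidazole Nitrogen

The compounds below may be only part of what the source reports. "The series", "measured", "known", "first", "only" and "open" are said of these compounds alone.

Compound 1 `CCn1ccnc1-c1cc(OC)c(OC)c(OC)c1` carries an ethyl group on an aromatic nitrogen of its five-membered ring. In a functional assay on HeLa cells (Homo sapiens) for antiproliferative activity, read by MTT assay, with a stated time of 72 h (a lower number here means a stronger inhibitor, a higher number a weaker inhibitor), compound 1 gives > 100000 nM, which is a limit of the assay rather than a number (the limit of > 100000 nM in this assay, at which 1 of the 2 values shown sits). Its companion compound 2 `COc1cc(-c2nccn2-c2ccc3[nH]ccc3c2)cc(OC)c1OC` bears an aryl group on the same nitrogen, and in this assay compound 2 gives 4400 nM. Compound 3 `COc1cc(-c2nccn2-c2ccc(Br)cc2)cc(OC)c1OC` has not yet been measured. Its change from compound 1 is 4-bromophenyl in place of ethyl on an aromatic nitrogen. For the measured compounds named here, no measured step between two compounds of this set exists, so the size of the effect must be estimated. A large gain is expected in this assay, in the direction of stronger inhibition, because compound 2 with its aryl group on the nitrogen gives 4400 nM. Compound 3 is therefore expected to give 6000 nM, in a range from 1200 nM to 30000 nM, a step of an at least 16-fold lower number from compound 1 to compound 3 (1.22 log units; beyond the scatter).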

Compound 3, half-maximal inhibitory concentration: 3300 nM
Beside the measured number, compound 3's estimate is 1.8-fold (0.26 log units) above it, within the range that was stated.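

For the compounds shown here, the change from ethyl to 4-bromophenyl on the aromatic nitrogen gives, in this assay, an at least 30-fold lower number from compound 1 to compound 3 (1.48 log units; beyond the scatter), the one step at this position that can be read directly between two compounds of the set. Its size is only a bound, because compound 1 sits at a limit of the assay: the limit of > 100000 nM in this assay, at which 1 of the 3 values shown sits. Compound 2 gives 4400 nM and compound 3 gives 3300 nM, values within the usual scatter of each other, so these two different aryl groups on this nitrogen cannot be told apart here.

The compounds shown leave open whether plain phenyl would match 4-bromophenyl, and how a benzyl group or a longer chain such as butyl on this nitrogen would compare. They also do not tell what chlorine or methoxy in place of the bromine would give.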